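A few compounds are considered here, and "the series" means these few. Any claim that something is new, unique, unknown or untested is made for them only; others in the source may bear on it.

Compound 1 `FC(F)(F)c1ccc(COc2ccc(Nc3ncnc4cc5c(cc34)OCCOCCOCCOCCO5)cc2)cc1` gives 3340 nM in a functional assay on HepG2 cells (Homo sapiens) for antiproliferative activity, read by MTT assay, with a stated time of 72 h; a higher number here means a weaker inhibitor, a lower number a stronger inhibitor.
Compound 2 `O=[N+]([O-])c1ccc(COc2ccc(Nc3ncnc4cc5c(cc34)OCCOCCOCCOCCO5)cc2)cc1` gives only a limit, > 100000 nM, in this assay.

Compound 2 thus sits at the limit of this assay the limit of > 100000 nM in this assay, at which 1 of the 2 values shown sits, with no number of its own, while compound 1 carries a measured value. Among the measured compounds shown here, the one measured step, an at least 29-fold higher number from compound 1 to compound 2 (1.47 log units; beyond the scatter), shows how strongly the group on this aromatic carbon can shift the result. Compound 3 `c1ccc(COc2ccc(Nc3ncnc4cc5c(cc34)OCCOCCOCCOCCO5)cc2)cc1` differs from compound 2 by hydrogen in place of nitro on an aromatic carbon. The expected step of an at least 5.0-fold lower number from compound 2 to compound 3 (0.69 log units; beyond the scatter) runs toward a lower number, because the change removes the nitro that marked an at least 29-fold higher number from compound 1 to compound 2 (1.47 log units; beyond the scatter). Compound 3 is estimated at 20000 nM, within 3000 nM to 100000 nM.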

Compound 3, half-maximal inhibitory concentration: 11900 nM
Compound 3: middle estimate off by 1.7-fold (0.23 log units), on the high side; the range from low to high includes it.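

With hydrogen on this carbon, this assay shows an at least 8.4-fold lower number from compound 2 to compound 3 (0.92 log units; beyond the scatter), and also a 3.6-fold higher number from compound 1 to compound 3 (0.55 log units; beyond the scatter), so hydrogen now serves as a reference point. Measured against it, trifluoromethyl goes with a lower number and nitro with a higher one, so the two groups move the result in opposite directions. The size of the nitro step stays open-ended, because compound 2 carries a limit and not a number: the limit of > 100000 nM in this assay, at which 1 of the 3 values shown sits.

Going by these compounds, whether an amine, a methoxy group or a carboxylic acid on this carbon would lower or raise the number remains open. So does whether trifluoromethyl and nitro would behave the same way elsewhere on this ring.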